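Series notes: sulfamoyl in place of bromo on the aryl

The source may report more compounds than this note shows. Statements on the series, on what has been measured and on what is new or still open speak of the compounds shown alone.

Measured compounds:
compound 1 `CCCCCCCCCCCCOc1cccc(N2C(N)=NC(N)=NC2(C)C)c1` 6.24
compound 2 `CC1(C)N=C(N)N=C(N)N1c1cccc(Br)c1` 5.9

Within the data shown here, in a functional assay on L5178Y cells (Mus musculus) (a higher number here means a more potent compound, by a factor of ten per unit of this negative logarithm, a lower number a less potent compound), compound 2 gives 5.9, the lower of the two numbers so far; compound 1 gives 6.24, a gap beyond the scatter. Compound 3 `CC1(C)N=C(N)N=C(N)N1c1cccc(S(N)(=O)=O)c1` is the next one to be measured in this assay. Its change from compound 2 is sulfamoyl in place of bromo on an aromatic carbon, the place being meta to a large group. Among the measured compounds shown here, no step between measured compounds shows what this change does, so the expectation rests on the shared core alone: a moderate drop, the step of a number 0.60 log units lower from compound 2 to compound 3 (beyond the scatter) being estimated in this assay. Compound 3 is expected to give 5.3, within 4.6 to 6.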

Compound 3, logarithm of the reciprocal of the active concentration, log(1/C): 3.13
The estimate for compound 3 lay 2.17 log units above the measured number; the measured number lies below the stated range.
By their numbers in this assay, from the lowest: compound 3; then compound 2; then compound 1.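

In this assay, among these compounds, sulfamoyl in place of bromo on the aromatic carbon meta to a large group gives a number 2.77 log units lower from compound 2 to compound 3 (beyond the scatter), the first reading of any change at this place. A step of this size shows that this place is far from indifferent to what it carries, and that bromo cannot be replaced freely here. Nothing at hand bears on the cause of this step.

On these data alone, whether the loss follows the whole sulfamoyl group or its nitrogen stays open. A methylsulfonyl group or a carboxylic acid at this place would help separate the two.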